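Ethynyl in place of methyl: expected effect on cytotoxicity

This account rests on a few compounds, and the source may have more. Where it says the series, first, only, none or still open, it means among the compounds named here.

Compound 3 `COc1ccc2c(OCC[C@@H]3NC(=O)N(C)CCCC/C=C\[C@@H]4C[C@@]4(C(=O)NS(=O)(=O)C4(C)CC4)NC3=O)cc(-c3nc(C(C)C)cs3)nc2c1Cl` was tested in an ADME assay on cells (Homo sapiens) for activation (on this read-out higher numbers stand for lower toxicity in this test and lower numbers for higher toxicity in this test), where compound 3 gives 37400 nM. Two close relatives are known. Compound 2 `COc1ccc2c(OCC[C@@H]3NC(=O)N(C)CCCC/C=C\[C@@H]4C[C@@]4(C(=O)NS(=O)(=O)C4(C)CC4)NC3=O)cc(-n3ccc(C(C)C)n3)nc2c1Cl` gives 31000 nM in this assay, and the step of a 1.2-fold higher number from compound 2 to compound 3 (0.08 log units; within the scatter) hardly moves the number. Compound 1 `COc1ccc2c(OCC[C@@H]3NC(=O)N(C)CCCC/C=C\[C@@H]4C[C@@]4(C(=O)NS(=O)(=O)C4(C#N)CC4)NC3=O)cc(-c3nc(C(C)C)cs3)nc2c1Cl` differs from compound 3 by a cyano in place of methyl on a saturated ring carbon. For compound 1 the read-out in this assay is only a limit, > 75000 nM. The step of an at least 2.0-fold lower number from compound 1 to compound 3 (0.30 log units; that floor lies within the scatter) thus points downward, resting on (the limit of > 75000 nM in this assay, at which 1 of the 3 values shown sits). Among the two plain numbers, compound 3 stands highest, yet its gap to compound 2 lies within the scatter, so the two cannot be ordered.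

Compound 4 `C#CC1(S(=O)(=O)NC(=O)[C@@]23C[C@H]2/C=C\CCCCN(C)C(=O)N[C@@H](CCOc2cc(-c4nc(C(C)C)cs4)nc4c(Cl)c(OC)ccc24)C(=O)N3)CC1` differs from compound 3 as follows: ethynyl in place of methyl on a saturated ring carbon. The measured step at the same saturated ring carbon is an at least 2.0-fold lower number from compound 1 to compound 3 (0.30 log units; that floor lies within the scatter), and moving away from methyl there is expected to raise the number modestly, by a 1.4-fold higher number from compound 3 to compound 4 (0.14 log units; within the scatter). Compound 4 is therefore expected to give 52000 nM, within a range from 25000 nM to 110000 nM.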

Compound 4, half-maximal cytotoxic concentration: 26300 nM
Beside the measured number, compound 4's estimate is 2.0-fold (0.30 log units) above it; low and high end bracket the measured number.
By their numbers in this assay, from the lowest: compounds 4, 2 and 3 (each within the scatter of the next). At a limit, above all of these: compound 1.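

At this saturated ring carbon, ethynyl and methyl cannot be told apart in this assay (a 1.4-fold lower number from compound 3 to compound 4 (0.15 log units; within the scatter)), so adding one carbon and a triple bond here leaves the read-out within the scatter. The new compound also sharpens the picture for cyano: the comparison with methyl had only a floor within the scatter, whereas the comparison with ethynyl clears it (an at least 2.8-fold lower number from compound 1 to compound 4 (0.45 log units; beyond the scatter)), which sets the cyano compound apart from both neighbours. That step still gives only a minimum size, and its reading for compound 1 is a limit rather than a number: (the limit of > 75000 nM in this assay, at which 1 of the 4 values shown sits).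

As far as these compounds go, whether an ethyl, a hydroxymethyl or an aminomethyl group at this carbon would stay with methyl and ethynyl or move towards cyano remains open. So does how far compound 1 actually lies from the others.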